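The compounds below may be only part of what the source reports. "The series", "measured", "known", "first", "only" and "open" are said of these compounds alone.

Of the compounds shown here, three built on one shared core have been measured in an assay for inhibition of Intestinal-type alkaline phosphatase (Homo sapiens), read by spectrophotometry, with stated times of 10 min and 20 min; a higher number here means a weaker inhibitor, a lower number a stronger inhibitor. Compound 1 `COc1ccccc1/C=C1\NS(=O)(=O)c2ccccc2C1=O` gives 1240 nM. Compound 2 `COc1cccc(/C=C2\NS(=O)(=O)c3ccccc3C2=O)c1` gives 1040 nM, and compound 3 `COc1ccc(/C=C2\NS(=O)(=O)c3ccccc3C2=O)cc1` gives 1530 nM. Compound 1 stands second highest of these three numbers, yet its gaps to compound 2 and to compound 3 both lie within the scatter, so no order among the three can be read from them.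

Compound 4 `O=C1/C(=C/c2ccccc2Br)NS(=O)(=O)c2ccccc21` differs from compound 1 by bromo in place of methoxy on an aromatic carbon. Among the measured compounds shown here, no measured pair shows what this change does on the shared core. In this assay the step expected is a 1.1-fold lower number from compound 1 to compound 4 (0.05 log units; within the scatter), no larger than the scatter, in either direction. Compound 4 is therefore expected to give 1100 nM, with a range from 400 nM to 3000 nM.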

Compound 4, half-maximal inhibitory concentration: 7430 nM
The estimate for compound 4 lay 6.8-fold (0.83 log units) below the measured number, outside the stated range (above it).
By their numbers in this assay, from the lowest: compounds 2, 1 and 3 (each within the scatter of the next); then compound 4.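

In this assay bromo in place of methoxy on an aromatic carbon, ortho to a large group, gives a 6.0-fold higher number from compound 1 to compound 4 (0.78 log units; beyond the scatter) and so moves the number beyond the scatter. The three methoxy compounds, all within the scatter of their neighbours, had shown no such sensitivity to what the ring carries. Nothing at hand bears on what lies behind this step.

Still open, from the compounds shown here alone, is whether the step reflects the loss of methoxy or the arrival of bromo, which a plain hydrogen, a fluoro or an amine on the same carbon could help separate. Among the compounds shown here, whether bromo on the other ring carbons carrying methoxy in the earlier compounds would give a similar step also remains unknown.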